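This account rests on a few compounds, and the source may have more. Where it says the series, first, only, none or still open, it means among the compounds named here.

Measured compounds:
compound 1 `Cc1ccc(NC(=O)CCCCCCCSc2nnc(Cc3nn(C)c(=O)c4ccccc34)n2C)c(Cl)c1`, an assay on cells for inhibition of IL15-IL15 receptor (Homo sapiens), read by AlphaScreen, with stated times of 30 min and 1 h (on this read-out higher numbers stand for weaker inhibition and lower numbers for stronger inhibition), 76000 nM
compound 2 `CCCOc1ccc(NC(=O)CCCCCCCSc2nnc(Cc3nn(C)c(=O)c4ccccc34)n2C)cc1`, this assay 40000 nM

Compound 2 holds the nearer-to-the-bottom of the two numbers, but the gap a 1.9-fold lower number from compound 1 to compound 2 (0.28 log units; within the scatter) is within the scatter, so the two cannot be ordered. Compound 3 `CC(C)Oc1ccc(NC(=O)CCCCCCCSc2nnc(Cc3nn(C)c(=O)c4ccccc34)n2C)cc1` carries isopropyl in place of propyl on an oxygen on an aromatic ring. Among the compounds with values here, no measured step touches that change; the one step known, a 1.9-fold lower number from compound 1 to compound 2 (0.28 log units; within the scatter), exchanged the whole aryl group on the amide nitrogen and still stayed within the scatter. A chain rearranged at the ether oxygen is therefore expected to give no step beyond the scatter, no change at the digits printed from compound 2 to compound 3 (within the scatter). Compound 3 is estimated at 40000 nM, range 15000 nM to 110000 nM.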

Compound 3, half-maximal inhibitory concentration: 93000 nM
For compound 3 the middle estimate is 2.3-fold (0.37 log units) below the measured one; low and high end bracket the measured number.
By their numbers in this assay, from the lowest: compounds 2, 1 and 3 (each within the scatter of the next, the first and the last beyond it).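

In this assay, within the data shown here, isopropyl in place of propyl on the oxygen gives the first step beyond the scatter (a 2.3-fold higher number from compound 2 to compound 3 (0.37 log units; beyond the scatter)), a modest one, although the same atoms are only joined differently. The aryl exchange on the amide nitrogen between the other pair stays within the scatter (a 1.2-fold higher number from compound 1 to compound 3 (0.09 log units; within the scatter)), so at this ether the arrangement of the chain changes the number. Nothing available bears on why this step arises. The compounds shown leave open how a longer chain on that oxygen, or an amine in place of the ether, would read.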